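Bromo for trifluoromethyl in a tolerance-limited series

The compounds below may be only part of what the source reports. "The series", "measured", "known", "first", "only" and "open" are said of these compounds alone.

Compound 1 `CS(=O)(=O)CCCn1c(Cn2c(=O)n(C3CC3)c3ccncc32)cc2cc(C(F)(F)F)ccc21` in an ADME assay on HeLa cells (Homo sapiens) for cytotoxicity, read by ATP content, with a stated time of 3 days (a higher number here means that more compound is tolerated, a lower number that less compound is tolerated), gives > 50000 nM, a limit of the assay rather than a number. Compound 2 `N#CCCCn1c(Cn2c(=O)n(-c3ccc(C(=O)NC4CC4)cc3)c3ccncc32)cc2cc(Cl)ccc21` in this assay gives > 50000 nM, likewise a limit. Among the compounds with values here, both values sit at the limit of > 50000 nM in this assay, at which 2 of the 2 values shown sit, so compound 1 stands at the limit, with no measured step to set against it. Compound 3 `CS(=O)(=O)CCCn1c(Cn2c(=O)n(C3CC3)c3ccncc32)cc2cc(Br)ccc21` differs from compound 1 by bromo in place of trifluoromethyl on an aromatic carbon. Within the data shown here, with no step between measured compounds available, the expected step of a number no higher from compound 1 to compound 3 (the limit leaves the size open) in this assay is none beyond the scatter. Compound 3 is expected to give 50000 nM, with a range from 20000 nM to 100000 nM, most likely again reported as a limit.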

Compound 3, half-maximal cytotoxic concentration: > 50000 nM
Compound 3 gave a limit, no number (the forecaster's own chance of this, stated with the estimate: 80%); the middle value lies on the limit itself.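

Compound 1 and compound 3 both stand at a limit, so no step can be read for bromo in place of trifluoromethyl: the limit of > 50000 nM in this assay, at which 3 of the 3 values shown sit. The compounds shown leave open the concentration at which any of them stops being tolerated in this assay.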